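Ethyl in place of the sugar on the ring nitrogen

The compounds below may be only part of what the source reports. "The series", "measured", "known", "first", "only" and "open" are said of these compounds alone.

Compound 2 `N#Cc1c(-c2ccc(Cl)cc2)cc(-c2ccc(Cl)cc2)n([C@@H]2O[C@H](CO)[C@@H](O)[C@H]2O)c1=O` carries the 3,4-dihydroxy-5-(hydroxymethyl)oxolan-2-yl group on the aromatic nitrogen of the shared core. Among the measured compounds shown here, in a functional assay on HepG2 cells (Homo sapiens) for cytotoxicity, read by sulforhodamine B assay, with a stated time of 48 h (a lower number here means a stronger inhibitor, a higher number a weaker inhibitor), compound 2 gives 6.9 ug/mL, the lowest of the three numbers so far. Compound 1 `C#CCn1c(-c2ccc(Cl)cc2)cc(-c2ccc(Cl)cc2)c(C#N)c1=O`, with propargyl on that nitrogen, gives 18.3 ug/mL in this assay, and compound 3 `N#Cc1c(-c2ccc(Cl)cc2)cc(-c2ccc(Cl)cc2)n([C@@H]2O[C@H](CO)[C@@H](O)[C@H](O)[C@H]2O)c1=O`, with 3,4,5-trihydroxy-6-(hydroxymethyl)oxan-2-yl there, gives 16.1 ug/mL. Both steps away from compound 2 are modest but beyond the scatter: a 2.7-fold lower number from compound 1 to compound 2 (0.42 log units; beyond the scatter) and a 2.3-fold higher number from compound 2 to compound 3 (0.37 log units; beyond the scatter).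

Compound 4 `CCn1c(-c2ccc(Cl)cc2)cc(-c2ccc(Cl)cc2)c(C#N)c1=O` is not yet measured. It differs from compound 2 in one place: ethyl in place of 3,4-dihydroxy-5-(hydroxymethyl)oxolan-2-yl on an aromatic nitrogen. For the measured compounds named here, no measured step exchanges the sugar for a short alkyl chain, so the nearest guide is compound 1, whose propargyl group is likewise a short chain without hydroxyl groups and whose 18.3 ug/mL sits a modest step above compound 2. Compound 4 is therefore expected to land near compound 1 rather than near compound 2, a modest move to a higher number in this assay.

For compound 4 the estimate in this assay is 16 ug/mL, with a range of 7 ug/mL to 35 ug/mL. This corresponds to an expected step of a 2.3-fold higher number from compound 2 to compound 4 (0.37 log units; beyond the scatter).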

Compound 4, half-maximal inhibitory concentration: 22.3 ug/mL
The estimate for compound 4 lay 1.4-fold (0.14 log units) below the measured number, within the range that was stated.
By their numbers in this assay, from the lowest: compound 2; then compounds 3, 1 and 4 (each within the scatter of the next).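

Among the compounds shown here, replacing the sugar with ethyl on the aromatic nitrogen gives the first direct sugar-to-saturated-alkyl comparison in this assay (a 3.2-fold higher number from compound 2 to compound 4 (0.51 log units; beyond the scatter)), and this step is beyond the scatter. Ethyl cannot be told apart from propargyl (a 1.2-fold higher number from compound 1 to compound 4 (0.09 log units; within the scatter)) or from the 3,4,5-trihydroxy-6-(hydroxymethyl)oxan-2-yl group (a 1.4-fold higher number from compound 3 to compound 4 (0.14 log units; within the scatter)), so at this position only the 3,4-dihydroxy-5-(hydroxymethyl)oxolan-2-yl group of compound 2 stands apart, and compound 3 shows that carrying a sugar does not in itself separate a compound from the two short chains. Nothing available accounts for these differences.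

The compounds shown leave open how a longer chain such as n-butyl, or a short chain ending in an amine or a carboxylic acid, would compare with ethyl on this nitrogen. Also open, from the compounds shown here alone, is whether the separation of compound 2 belongs to this particular oxolan-2-yl group or would extend to a five-membered sugar with other stereocentres or with its hydroxymethyl replaced by methyl.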